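Hydrazone series: trihydroxyphenyl for chlorophenyl on the shorter chain

This account rests on a few compounds, and the source may have more. Where it says the series, first, only, none or still open, it means among the compounds named here.

Compound 1 `O=C(CCc1nc2ccccc2c(=O)[nH]1)N/N=C/c1ccc(Cl)cc1` is the weakest of the three measured compounds: in a physicochemical assay, read by spectrophotometry, with a stated time of 30 min (a lower number here means a stronger inhibitor, a higher number a weaker inhibitor), compound 1 gives 381000000 nM, the highest of the three numbers, with compound 2 `O=C(CCCc1nc2ccccc2c(=O)[nH]1)N/N=C/c1ccc(O)c(O)c1` nearest at 95000000 nM and compound 3 `O=C(CCCc1nc2ccccc2c(=O)[nH]1)N/N=C/c1cc(O)c(O)c(O)c1` furthest at 78000000 nM. Compounds 2 and 3 carry a chain one carbon longer than compound 1, so their gap to compound 1 mixes two changes and is read only for what the values show. For the measured compounds named here, the one single-point step, a 1.2-fold lower number from compound 2 to compound 3 (0.09 log units; within the scatter), adds a hydroxy on an aromatic carbon and stays within the scatter.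

Compound 4 `O=C(CCc1nc2ccccc2c(=O)[nH]1)N/N=C/c1cc(O)c(O)c(O)c1` is compound 1 with 3,4,5-trihydroxyphenyl in place of 4-chlorophenyl on a carbon with a double bond to nitrogen. The trihydroxyphenyl of compound 4 is that of compound 3; the chain is that of compound 1. A step beyond the scatter toward a lower number is expected, since compounds 2 and 3 both sit well below compound 1, while the shorter chain keeps the estimate above compound 3. Compound 4 is expected to give 110000000 nM in this assay, within 45000000 nM to 270000000 nM, a step of a 3.5-fold lower number from compound 1 to compound 4 (0.54 log units; beyond the scatter).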

Compound 4, half-maximal inhibitory concentration: 81000000 nM
For compound 4 the middle estimate is 1.4-fold (0.13 log units) above the measured one, within the range that was stated.
By their numbers in this assay, from the lowest: compounds 3, 4 and 2 (each within the scatter of the next); then compound 1.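

For the compounds shown here, on the shorter chain, 3,4,5-trihydroxyphenyl in place of 4-chlorophenyl on a carbon with a double bond to nitrogen comes with a 4.7-fold lower number from compound 1 to compound 4 (0.67 log units; beyond the scatter) in this assay and is the first single-place change to go beyond the scatter, whereas the earlier added hydroxy stayed within it. With the same 3,4,5-trihydroxyphenyl, compound 4 gives 81000000 nM and compound 3, on the longer chain, gives 78000000 nM and these two values lie within the scatter of each other. No measurement at hand accounts for the step.

The step joins the loss of the chlorine with the gain of the hydroxy groups, and the values do not separate the two. On these data alone, whether plain phenyl, 4-methoxyphenyl or an aminophenyl on the shorter chain would give a similar number stays open.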